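The compounds below may be only part of what the source reports. "The series", "measured", "known", "first", "only" and "open" are said of these compounds alone.

Measured compounds: compound 1 `N#Cc1ccc(-n2ncc3c(N)ncnc32)cc1`, "not determined" (no result reported); compound 2 `Nc1ncnc2c1cnn2-c1ccc(C(F)(F)F)cc1`, "not determined" (no result reported); compound 3 `CC(=O)OC[C@H]1O[C@@H](Nc2ncnc3c2cnn3-c2ccc(C(=O)O)cc2)[C@H](OC(C)=O)[C@@H](OC(C)=O)[C@@H]1OC(C)=O`, > 150000 nM.

In a functional assay on MCF7 cells (Homo sapiens) for inhibition, with a stated time of 48 h (a higher number here means a weaker inhibitor of growth, a lower number a stronger inhibitor of growth), compound 1 gives "not determined" (no result reported), so no number places it among the others. Compound 2 likewise gives "not determined" (no result reported) in this assay. Compound 3 gives only a limit in this assay, namely > 150000 nM; one of the three entries sits at this limit (the limit of > 150000 nM in this assay, at which 1 of the 3 values shown sits). The change from compound 1 to compound 4 `COc1ccc(-n2ncc3c(N)ncnc32)cc1` is methoxy in place of cyano on an aromatic carbon. For the measured compounds named here, with no measured pair to draw on, neither the direction nor the size of the shift in this assay can be read from the data, and it may well stay within the scatter. Compound 4 is expected to give about 60000 nM in this assay, within a range from 5000 nM to 200000 nM.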

Compound 4, concentration for 50% growth inhibition: > 150000 nM
Compound 4: only a limit was reported; the forecaster's own chance of this, stated with the estimate: 55%; middle value at least 2.5-fold (0.39 log units) away from the limit.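

In this assay compound 4 gives only a limit, > 150000 nM. For the compounds shown here, compound 1 has no single number, so no step between compound 1 and compound 4 can be read. The compounds shown leave open whether any change on the shared core shifts growth inhibition: the limit of > 150000 nM in this assay, at which 2 of the 4 values shown sit.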